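The source may report more compounds than this note shows. Statements on the series, on what has been measured and on what is new or still open speak of the compounds shown alone.

Of the compounds shown here, three sharing one core have been tested in a functional assay on B16-F10 cells (Mus musculus) for antiproliferative activity, read by MTT assay, with a stated time of 48 h; on this read-out lower numbers stand for stronger inhibition and higher numbers for weaker inhibition. Compound 1 `CCCC(C)Oc1ccc(C(=O)/C=C/c2c(/C=C/c3ccc(OC)cc3)cc(OC)cc2OC)cc1` gives 6.7 ug/mL. Compound 2 `CCCCOc1ccc(C(=O)/C=C/c2c(/C=C/c3ccc(OC)cc3)cc(OC)cc2OC)cc1` gives 5.3 ug/mL, and compound 3 `COc1ccc(/C=C/c2cc(OC)cc(OC)c2/C=C/C(=O)c2ccc(F)cc2)cc1` gives 5.3 ug/mL. Compound 2 stands level with compound 3, and the step of a 1.3-fold lower number from compound 1 to compound 2 (0.10 log units; within the scatter) is within the scatter, so all three numbers sit together.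

Compound 4 `COc1ccc(/C=C/c2cc(OC)cc(OC)c2/C=C/C(=O)c2ccc(Cl)cc2)cc1` differs from compound 2 in one place: chloro in place of butoxy on an aromatic carbon. The nearest guide is the step of no change at the digits printed from compound 2 to compound 3 (within the scatter), where the butoxy group also gave way to a single halogen atom; the step of a 1.3-fold lower number from compound 1 to compound 3 (0.10 log units; within the scatter) points the same way. A change of the same kind is therefore expected to give no step beyond the scatter in this assay, and the step of no change at the digits printed from compound 2 to compound 4 (within the scatter) is the estimate. Compound 4 is expected to give 5.3 ug/mL, between 2.7 ug/mL and 10.6 ug/mL.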

Compound 4, half-maximal inhibitory concentration: 4.9 ug/mL
For compound 4 the middle estimate is 1.1-fold (0.03 log units) above the measured one; low and high end bracket the measured number.
By their numbers in this assay, from the lowest: compounds 4, 2, 3 and 1 (each within the scatter of the next).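

In this assay, a second halogen now joins the comparison at this position: the change from 4-butoxyphenyl to 4-chlorophenyl gives a 1.1-fold lower number from compound 2 to compound 4 (0.03 log units; within the scatter), chloro in place of fluoro gives a 1.1-fold lower number from compound 3 to compound 4 (0.03 log units; within the scatter), and chloro in place of 1-methylbutoxy gives a 1.4-fold lower number from compound 1 to compound 4 (0.14 log units; within the scatter). Butoxy, 1-methylbutoxy, fluoro and chloro at this position therefore all give numbers within the scatter of one another. No measurement at hand explains this.

On these data alone, whether an amine, a carboxylic acid or a much longer chain at this position would stay within the same range remains open.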